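Same atoms, joined differently: from compound 1 to compound 3

The compounds below may be only part of what the source reports. "The series", "measured", "known", "first", "only" and "open" are said of these compounds alone.

Of the compounds shown here, two have been measured so far in an ADME assay on MDCK cells (Canis lupus familiaris) for cytotoxicity, with a stated time of 48 h; a lower number here means that less compound is tolerated, a higher number that more compound is tolerated. Compound 1 (`C=C(C(=O)Nc1ccc(B(O)O)cc1)[C@@H]1CC[C@H](C)[C@@H]2CC(=O)C(C)=C2C1`) gives 939 uM and stands as the higher of the two numbers. Compound 2 (`C=C(C(=O)NCc1ccc(B(O)O)cc1)[C@@H]1CC[C@H](C)[C@@H]2CC(=O)C(C)=C2C1`) gives 262 uM in this series, a lower number and beyond the scatter. Among the compounds with values here, these two compounds do not form a single-place step, so no measured step is available as a guide.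

Compound 3 (`C=C(C(=O)Nc1cccc(B(O)O)c1)[C@@H]1CC[C@H](C)[C@@H]2CC(=O)C(C)=C2C1`) has the same atoms as compound 1, joined differently (a group of 9 heavy atoms (6 carbon, 1 boron, 2 oxygen; one six-membered aromatic ring of carbon only) in place of a group of 9 heavy atoms (6 carbon, 1 boron, 2 oxygen; one six-membered aromatic ring of carbon only), on an amide-type nitrogen) while the shared core stays the same. The group on the amide-type nitrogen keeps its heavy-atom count, its six-membered aromatic ring of carbon only and its boron, so no step beyond the scatter is expected in this assay for this change. Within the data shown here, with only two measured values, that expectation remains weak. The expected step is a 1.3-fold lower number from compound 1 to compound 3 (0.13 log units; within the scatter) and would lie within the scatter, with a slight lean to a lower number. For compound 3 the estimated value is 700 uM with an expected range of 300 uM to 1500 uM in this assay.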

Compound 3, half-maximal toxic concentration: 632 uM
For compound 3 the middle estimate is 1.1-fold (0.04 log units) above the measured one, within the range that was stated.
By their numbers in this assay, from the lowest: compound 2; then compounds 3 and 1 (each within the scatter of the next).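

In this assay the series now has its first step that differs in one place: a 1.5-fold lower number from compound 1 to compound 3 (0.17 log units; within the scatter) stays within the scatter, so the two compounds cannot be told apart by this read-out. At this place, on an amide-type nitrogen whose other neighbour is the carbonyl carbon, joining the same atoms of the group differently gives no readable change, with the heavy-atom count, the six-membered aromatic ring of carbon only and the boron all kept. Nothing measured on these compounds speaks to the reason for this result.

Open still is whether the boron-bearing group matters to the number at all, since a carboxylic acid or an amine on the same aromatic ring in its place would show whether a step beyond the scatter can arise at this nitrogen. Also open, as far as these compounds go, is whether the same rejoining of atoms would stay as small on the group of compound 2, and a longer chain on the amide-type nitrogen would add a further reading of how this place responds.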